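A few compounds are considered here, and "the series" means these few. Any claim that something is new, unique, unknown or untested is made for them only; others in the source may bear on it.

Measured so far:
compound 1 `COc1c(Cl)ccc2c1CCC2c1ncc[nH]1`: > 10000 nM
compound 2 `c1cc(-c2nccs2)c2c(c1)C(c1ncc[nH]1)CC2`: 3190 nM

Within the data shown here, in a functional assay on CHO cells for agonist activity at Alpha-1D adrenergic receptor (Homo sapiens), read by FLIPR and calcium flux (a lower number here means that less compound is needed, a higher number that more compound is needed for the effect), compound 2 gives 3190 nM, the only actual number among the two values shown. For compound 1 the result in this assay is a limit of the assay, (the limit of > 10000 nM in this assay, at which 1 of the 2 values shown sits). Compound 3 `c1ccc(-c2cccc3c2CCC3c2ncc[nH]2)nc1` differs from compound 2 by pyridin-2-yl in place of 1,3-thiazol-2-yl on an aromatic carbon. Among the measured compounds shown here, no measured pair of compounds covers such a change, so its effect can only be guessed; in this assay no shift beyond the usual scatter is expected in either direction. Compound 3 is estimated at 4000 nM in this assay, with a range from 1000 nM to 15000 nM. The expected step is a 1.3-fold higher number from compound 2 to compound 3 (0.10 log units; within the scatter).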

Compound 3, half-maximal effective concentration: > 10000 nM
Compound 3: only a limit was reported; the forecaster's own chance of this, stated with the estimate: 25%; middle value at least 2.5-fold (0.39 log units) away from the limit.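

At this aromatic carbon the ring is not freely interchangeable: pyridin-2-yl in place of 1,3-thiazol-2-yl gives an at least 3.1-fold higher number from compound 2 to compound 3 (0.49 log units; beyond the scatter) in this assay. Among the compounds shown, only compound 2, with its 1,3-thiazol-2-yl group, gives an actual number. The result for compound 3 is a limit of the assay and not a number, leaving the true size of the step unknown: the limit of > 10000 nM in this assay, at which 2 of the 3 values shown sit.

From the compounds shown here alone, whether the ring size or the sulfur atom matters more remains open, as this change alters both. Going by these compounds, how a group such as furan-2-yl or a simple amine would behave at this carbon is also open.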